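Chain variation on the amino substituent of the shared core

A few compounds are considered here, and "the series" means these few. Any claim that something is new, unique, unknown or untested is made for them only; others in the source may bear on it.

Compound 1 `CCCCNc1nc(SC)nc2ncccc12` carries a butylamino group on the shared core. In a functional assay (Nicotiana tabacum) (on this read-out higher numbers stand for weaker inhibition and lower numbers for stronger inhibition), compound 1 gives 270 nM. Compound 2 `CCCCCCNc1nc(SC)nc2ncccc12` extends that chain; in this assay compound 2 gives 3330 nM. Among the two numbers measured so far, compound 1 stands lowest, the only step away from it being a 12-fold higher number from compound 1 to compound 2 (1.09 log units; beyond the scatter).

Compound 3 `CCOCCNc1nc(SC)nc2ncccc12` is the next case. The difference from compound 1 is ethoxy in place of ethyl on a saturated chain carbon, two bonds along the chain from a nitrogen on an aromatic ring, so the butylamino group becomes a (2-ethoxyethyl)amino group.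

Among the compounds with values here, no measured step covers an ethoxy for ethyl exchange at this place. Within the data shown here, the one step available, from compound 1 to compound 2, concerns ethyl in place of hydrogen four bonds along the chain, and it was large and towards weaker inhibition; it does not describe the present change, which keeps the butyl-length chain and introduces an oxygen. The expectation in this assay is therefore a step of about a 1.7-fold higher number from compound 1 to compound 3 (0.22 log units; within the scatter), possibly none beyond the scatter. Compound 3 is estimated at 450 nM, with a range from 150 nM to 1500 nM.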

Compound 3, half-maximal inhibitory concentration: 7590 nM
Estimate against measurement, compound 3: 17-fold (1.23 log units) below; measured number outside the range, above it.
By their numbers in this assay, from the lowest: compound 1; then compound 2; then compound 3.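

In this assay, the position on a saturated chain carbon, two bonds along the chain from a nitrogen on an aromatic ring, proves sensitive to ethoxy in place of ethyl: the exchange gives a 28-fold higher number from compound 1 to compound 3 (1.45 log units; beyond the scatter), even though the new group adds only one heavy atom, an oxygen. Within the data shown here, the series now shows that extending the chain is not the only change at this amino substituent that moves the number strongly upwards, and the (2-ethoxyethyl)amino group also stands above the longer chain, with a 2.3-fold higher number from compound 2 to compound 3 (0.36 log units; beyond the scatter), so the butylamino group of compound 1 remains lowest of the three. No measurement on these groups is available that bears on why the ethoxy exchange acts so strongly.

The compounds shown leave open whether a shorter chain such as propyl, or a branched chain such as isobutyl, would give a number lower than or close to that of compound 1. They also leave open how a methoxy group, a hydroxyl or an amine at the end of the chain would compare with the ethoxy group of compound 3.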